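This account rests on a few compounds, and the source may have more. Where it says the series, first, only, none or still open, it means among the compounds named here.

Measured compounds:
- compound 1 `COC1CN(C(=O)/C=C/c2ccncc2-c2ccc3[nH]ncc3c2)C1` in a functional assay on HCT-116 cells (Homo sapiens) for inhibition, read by MTT assay, with a stated time of 72 h; on this read-out lower numbers stand for stronger inhibition of growth and higher numbers for weaker inhibition of growth: "not determined" (no result reported)
- compound 2 `COC1CN(C(=O)/C=C/c2ccncc2-c2ccc3ccccc3c2)C1` in this assay: > 30000 nM
- compound 3 `CN1CCN(c2ccc(Nc3cnccc3/C=C/C(N)=O)cc2)CC1` in this assay: "not determined" (no result reported)

Only compound 2 has an entry with a number attached, and that entry is a limit of the assay rather than a measured value: compound 2 sits at the limit of > 30000 nM in this assay, at which 1 of the 3 values shown sits. Compound 1 and compound 3 carry no result. Compound 4 `CN1CCN(C(=O)/C=C/c2ccncc2-c2ccc3ccccc3c2)CC1` is the next compound to be measured in this assay. It differs from compound 2 in one place: 4-methylpiperazin-1-yl in place of 3-methoxyazetidin-1-yl on a carbonyl carbon. Among the measured compounds shown here, no step between two measured compounds is available to calibrate this change, so the step from compound 2 to compound 4 is expected to be none beyond the scatter, as expressed in a number no higher from compound 2 to compound 4 (the limit leaves the size open). Compound 4 is therefore expected to give about 30000 nM, within a range from 8000 nM to 100000 nM, most likely reported again as a limit.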

Compound 4, concentration for 50% growth inhibition: > 30000 nM
Compound 4 was reported as a limit; the forecaster's own chance of this, stated with the estimate: 70%; the middle value lies on the limit itself.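

Among the compounds shown here, no step between compound 2 and compound 4 can be read in this assay, where both entries are limits: the limit of > 30000 nM in this assay, at which 2 of the 4 values shown sit.
The compounds shown leave open whether exchanging 3-methoxyazetidin-1-yl for 4-methylpiperazin-1-yl alters growth inhibition at all.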